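The source may hold more compounds than are shown below. What is called first, only, known or untested is meant among the compounds shown, and "the series" means these compounds.

In a functional assay on MIA PaCa-2 cells (Homo sapiens) for antiproliferative activity, read by sulforhodamine B assay, with a stated time of 48 h (on this read-out higher numbers stand for weaker inhibition of growth and lower numbers for stronger inhibition of growth), compound 1 `O=C(NCc1cn(Cc2ccc(Cl)cc2)nn1)c1cn(-c2ccccc2)nc1-c1ccc(F)cc1` gives 280 nM. Among the three measured compounds this is the second highest number. Compound 3 `COc1cc(Cn2cc(CNC(=O)c3cn(-c4ccccc4)nc3-c3ccc(F)cc3)nn2)cc(OC)c1` gives 190 nM, with a 1.5-fold lower number from compound 1 to compound 3 (0.17 log units; within the scatter), a difference that cannot be separated from repeat scatter. Compound 2 `COc1ccc(Cn2cc(CNC(=O)c3cn(-c4ccccc4)nc3-c3ccc(F)cc3)nn2)cc1` gives 3700 nM, with a 13-fold higher number from compound 1 to compound 2 (1.12 log units; beyond the scatter), and the comparison of compound 2 with compound 3 shows a 19-fold lower number from compound 2 to compound 3 (1.29 log units; beyond the scatter).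

Compound 4 `COc1ccc(-c2nn(-c3ccccc3)cc2C(=O)NCc2cn(Cc3ccc(Cl)cc3)nn2)cc1` differs from compound 1 in one place: methoxy in place of fluoro on an aromatic carbon. Among the measured compounds shown here, all three measured steps change the group on the saturated chain carbon bound to the aromatic nitrogen, not the ring attached to the core, so no measured step reads directly on this change. For the measured compounds named here, the one step in which a methoxy enters, a 13-fold higher number from compound 1 to compound 2 (1.12 log units; beyond the scatter), replaces chloro and sits on the other ring; it is a weak guide at best. Going by the values given here, with no closer precedent, a modest move toward a higher number is taken as the working guess, with a wide range on either side.

Compound 4 is therefore expected to give about 600 nM in this assay, with a range from 150 nM to 2500 nM. This corresponds to an expected step of a 2.1-fold higher number from compound 1 to compound 4 (0.33 log units; beyond the scatter).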

Compound 4, concentration for 50% growth inhibition: 26300 nM
Compound 4: the middle estimate sits 44-fold (1.64 log units) below what was measured, outside the stated range (above it).
By their numbers in this assay, from the lowest: compounds 3 and 1 (each within the scatter of the next); then compound 2; then compound 4.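

In this assay, among the compounds shown here, the position para to a large group on the six-membered aromatic ring, which no earlier step touched, proves highly sensitive: 4-fluorophenyl to 4-methoxyphenyl gives a 94-fold higher number from compound 1 to compound 4 (1.97 log units; beyond the scatter). Together with a 13-fold higher number from compound 1 to compound 2 (1.12 log units; beyond the scatter), this shows methoxy in place of a halogen raising the number at two separate places on the background of compound 1, although the two changes differ in the halogen that leaves and in the ring that carries them. Compound 3 goes against any general penalty for methoxy on the ring of the other change, since a 1.5-fold lower number from compound 1 to compound 3 (0.17 log units; within the scatter) shows that the 3,5-dimethoxyphenyl group can stand in place of 4-chlorophenyl without a difference outside the scatter.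

No supporting measurement bears on why the fluoro-to-methoxy change has this effect. Still open, as far as these compounds go, are whether the step follows from losing fluoro or from gaining methoxy, which a hydroxy, ethoxy or chloro group at this position could help separate, and whether the same step holds on the backgrounds of compound 2 and compound 3.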